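From 4-chlorophenyl to cyclohexyl at one nitrogen

The source may report more compounds than this note shows. Statements on the series, on what has been measured and on what is new or still open speak of the compounds shown alone.

Measured in a functional assay on HCT-116 cells (Homo sapiens) for antiproliferative activity, read by MTT assay, with a stated time of 72 h; on this read-out lower numbers stand for stronger inhibition and higher numbers for weaker inhibition:
- Compound 1 `COc1cccc(N2C(=O)COc3ccc(-c4cnc(Cl)c(NS(=O)(=O)c5ccc(F)cc5)c4)cc32)c1`: > 40000 nM, a limit
- Compound 2 `COc1ncc(-c2ccc3c(c2)N(c2ccc(F)cc2)C(=O)CO3)cc1NS(=O)(=O)c1ccc(F)cc1`: > 40000 nM, a limit
- Compound 3 `O=C1COc2ccc(-c3cccc(NS(=O)(=O)c4ccc(F)cc4)c3)cc2N1c1ccc(Cl)cc1`: 23900 nM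

Among the compounds with values here, compound 3 is the only compound here with an actual number, 23900 nM. Compound 1 and compound 2 sit at the limit of > 40000 nM in this assay, at which 2 of the 3 values shown sit.

Compound 4 `O=C1COc2ccc(-c3cccc(NS(=O)(=O)c4ccc(F)cc4)c3)cc2N1C1CCCCC1` carries cyclohexyl in place of 4-chlorophenyl on an amide-type nitrogen in a ring. Within the data shown here, no measured pair here shows a change of this kind, so the expectation in this assay is loose. Little room is expected for a large shift, and a small move toward weaker inhibition seems likeliest. The estimated step is modest: a 1.3-fold higher number from compound 3 to compound 4 (0.10 log units; within the scatter). Compound 4 is estimated at 30000 nM, with an expected range from 12000 nM to 60000 nM.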

Compound 4, half-maximal inhibitory concentration: 18300 nM
For compound 4 the middle estimate is 1.6-fold (0.21 log units) above the measured one; the range from low to high includes it.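

In this assay, replacing 4-chlorophenyl with cyclohexyl on the amide-type nitrogen gives a 1.3-fold lower number from compound 3 to compound 4 (0.12 log units; within the scatter). This first single-place comparison shows that, at this position, a non-aromatic carbon ring can stand in for an aromatic one without a change beyond the usual scatter. Only compound 3 and compound 4 give actual numbers, and the other two values are limits: the limit of > 40000 nM in this assay, at which 2 of the 4 values shown sit.

From the compounds shown here alone, it remains open whether a group without a ring, such as methyl or a longer alkyl chain, would behave the same way here. Going by these compounds, a chain carrying an amine is equally open.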